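Pyrimidin-5-yl in place of pyridin-3-yl on compound 2

The source may hold more compounds than are shown below. What is called first, only, known or untested is meant among the compounds shown, and "the series" means these compounds.

Compound 1 `COc1ccc(-c2cc(NC(=O)Nc3ccncc3)cc(OC)c2OC)cn1`: "not determined" (no result reported) 
Compound 2 `O=C(Nc1ccncc1)Nc1cc(-c2cccnc2)ccc1OC(F)(F)F`: 39800 nM 

Within the data shown here, in a functional assay on A549 cells (Homo sapiens) for inhibition, read by MTT assay, with a stated time of 48 h (a lower number here means a stronger inhibitor, a higher number a weaker inhibitor), compound 2 (39800 nM) holds the only number so far, as compound 1 has no result. Compound 3 `O=C(Nc1ccncc1)Nc1cc(-c2cncnc2)ccc1OC(F)(F)F` is not yet measured and carries pyrimidin-5-yl in place of pyridin-3-yl on an aromatic carbon in the otherwise shared structure. Among the measured compounds shown here, no measured step speaks to this change, so no shift beyond the scatter is expected in this assay, in either direction. The estimated step of a 1.0-fold higher number from compound 2 to compound 3 (0.00 log units; within the scatter) therefore stays small. Compound 3 is estimated at 40000 nM (expected range 16000 nM to 100000 nM) for now.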

Compound 3, half-maximal inhibitory concentration: 3750 nM
The estimate for compound 3 lay 11-fold (1.03 log units) above the measured number; measured number below the stated range.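

The aromatic carbon para to the trifluoromethoxy group is sensitive to the ring it carries: in this assay, pyrimidin-5-yl in place of pyridin-3-yl gives an 11-fold lower number from compound 2 to compound 3 (1.03 log units; beyond the scatter). A ring with 2 hetero atoms replacing one with 1, at an unchanged heavy-atom count, is enough to move the number beyond the scatter. Nothing at hand explains this step.

Open, on these data alone, is how a plain phenyl ring, or a pyridin-3-yl ring bearing an amine, would read at this position. As far as these compounds go, whether the step carries over to other cores, such as that of compound 1, also remains open.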